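The source may hold more compounds than are shown below. What is called first, only, known or untested is meant among the compounds shown, and "the series" means these compounds.

Measured so far in a functional assay on SW-620 cells (Homo sapiens) for cytotoxicity; on this read-out higher numbers stand for weaker inhibition of growth and lower numbers for stronger inhibition of growth:
- compound 1 `COc1ccc(C2=C(c3ccc(SC)cc3)CC3CCCN3C2=O)cc1O`: 20000 nM
- compound 2 `COc1ccc(C2=C(c3ccc(SC)cc3)CC3CCCN3C2=O)cc1OC(=O)CNC(=O)OC(C)(C)C`: 20000 nM
- compound 3 `COc1ccc(C2=C(c3ccc(SC)cc3)CC3CCCN3C2=O)cc1C`: 500 nM

Of these three, compound 3 gives the lowest number, 500 nM, and so the strongest inhibition of growth. Compound 4 `COc1ccc(C2=C(c3ccc(SC)cc3)CC3CCCN3C2=O)cc1OC` has not been measured. It differs from compound 3 in one place: methoxy in place of methyl on an aromatic carbon. Among the compounds with values here, no measured step makes this exact change. The nearest evidence is a 40-fold lower number from compound 1 to compound 3 (1.60 log units; beyond the scatter) and a 40-fold lower number from compound 2 to compound 3 (1.60 log units; beyond the scatter), both large steps that remove an oxygen from that carbon, while no change at the digits printed from compound 1 to compound 2 (within the scatter) keeps the oxygen. Compound 4 puts an oxygen back, so a rise in the number is expected, probably smaller than those steps. The expected step is a 4.0-fold higher number from compound 3 to compound 4 (0.60 log units; beyond the scatter). For compound 4 the estimated value is 2000 nM, with an expected range of 300 nM to 15000 nM.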

Compound 4, concentration for 50% growth inhibition: 3000 nM
For compound 4 the middle estimate is 1.5-fold (0.18 log units) below the measured one; the range from low to high includes it.
By their numbers in this assay, from the lowest: compound 3; then compound 4; then compounds 1 and 2 (each within the scatter of the next).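

In this assay, the group on this oxygen matters: methyl in place of hydrogen gives a 6.7-fold lower number from compound 1 to compound 4 (0.82 log units; beyond the scatter) and methyl in place of (((tert-butoxycarbonyl)amino)methyl)carbonyl gives a 6.7-fold lower number from compound 2 to compound 4 (0.82 log units; beyond the scatter) as a step of the same size. Methoxy still falls short of methyl on this carbon, with a 6.0-fold higher number from compound 3 to compound 4 (0.78 log units; beyond the scatter) as the cost of the oxygen, so compound 4 sits between the earlier extremes. Nothing here explains these differences. Still open, as far as these compounds go, is whether a longer chain such as ethoxy, or an amine or chlorine on this carbon, would match methyl or methoxy.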